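The source may report more compounds than this note shows. Statements on the series, on what has been measured and on what is new or still open speak of the compounds shown alone.

Within the data shown here, compound 1 `COc1ccc(N2C(=O)NC3(CSC4=C3C(=O)c3ncccc3C4=O)C2=O)cc1` stands as the weaker of the two measured members: in a functional assay on CCRF-SB cells (Homo sapiens) for antiproliferative activity, read by MTT assay, with a stated time of 96 h (on this read-out higher numbers stand for weaker inhibition and lower numbers for stronger inhibition), compound 1 gives 10 nM, whereas compound 2 `O=C1NN(c2ccc([N+](=O)[O-])cc2)C(=O)C2(CSC3=C2C(=O)c2ncccc2C3=O)N1` gives 2 nM, a gap beyond the usual scatter. Compound 3 `O=C1C2=C(C(=O)c3ncccc31)C1(CS2)NC(=O)N(c2ccncc2)C1=O` differs from compound 1 by a single change: pyridin-4-yl in place of 4-methoxyphenyl on an amide-type nitrogen in a ring. Among the measured compounds shown here, no measured pair shows this change, so nothing in the data fixes its size. In this assay the expected step is a 1.5-fold higher number from compound 1 to compound 3 (0.18 log units; within the scatter), small and within the scatter, if anything toward a higher number. Compound 3 is therefore estimated at 15 nM, with a range from 5 nM to 50 nM.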

Compound 3, half-maximal inhibitory concentration: 1 nM
Compound 3: middle estimate off by 15-fold (1.18 log units), on the high side; measured number below the stated range.
By their numbers in this assay, from the lowest: compounds 3 and 2 (each within the scatter of the next); then compound 1.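

Pyridin-4-yl in place of 4-methoxyphenyl on the amide-type nitrogen in the ring gives a 10-fold lower number from compound 1 to compound 3 (1.00 log units; beyond the scatter) in this assay. This position therefore responds strongly to the group it carries, and a six-membered aromatic ring with a hetero atom is accepted here without loss. No available data bear on the reason for this step.

The change removes the methoxy group and introduces the ring nitrogen together, so their separate contributions remain unresolved. Plain phenyl or pyridin-3-yl at this position would be the informative comparisons.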